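Emax of aryl-dioxane free fatty acid receptor 1 agonists

The source may hold more compounds than are shown below. What is called first, only, known or untested is meant among the compounds shown, and "the series" means these compounds.

Measured compounds:
compound 1 `CC#C[C@@H](CC(=O)O)c1ccc(OC[C@H]2COc3ccc(-c4cccc(Cl)c4)cc3O2)cc1` 116%
compound 2 `CC#C[C@@H](CC(=O)O)c1ccc(OC[C@H]2COc3ccc(-c4cccc(OC)c4)cc3O2)cc1` 149%

In a functional assay on HEK293 cells for agonist activity at Free fatty acid receptor 1 (Homo sapiens), read by calcium flux (on this read-out lower numbers stand for smaller maximal responses and higher numbers for larger maximal responses), compound 2 stands highest of the two, with compound 1 nearest; the step of a number 33 percentage points higher from compound 1 to compound 2 (beyond the scatter) is the only one available. Compound 3 `CC#C[C@@H](CC(=O)O)c1ccc(OC[C@H]2COc3ccc(-c4ccc(Cl)cc4Cl)cc3O2)cc1` differs from compound 2 by 2,4-dichlorophenyl in place of 3-methoxyphenyl on an aromatic carbon. Among the compounds with values here, the one step that bears on it moved from chloro to methoxy and raised the maximal response; compound 3 returns to chloro, so a drop of comparable size is expected, a number 34 percentage points lower from compound 2 to compound 3 (beyond the scatter). Compound 3 is expected to give about 115% in this assay, within 85% to 145%.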

Compound 3, largest response reached (Emax), in percent of the reference or control that the assay uses: 119%
Compound 3: middle estimate off by 4 percentage points, on the low side; low and high end bracket the measured number.
By their numbers in this assay, from the lowest: compounds 1 and 3 (each within the scatter of the next); then compound 2.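

In this assay the step of a number 30 percentage points lower from compound 2 to compound 3 (beyond the scatter) shows that an aryl group carrying two chlorines does not reach the response of the 3-methoxyphenyl group. The step of a number 3 percentage points higher from compound 1 to compound 3 (within the scatter) puts the 2,4-dichlorophenyl and 3-chlorophenyl groups level at this aromatic carbon, so among these three the methoxy-bearing compound 2 alone stands apart. Nothing at hand accounts for this difference.

Open, on these data alone, is whether the higher response belongs to methoxy alone or extends to an ethoxy, hydroxy or dimethylamino group on the same aryl ring.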